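The compounds below may be only part of what the source reports. "The series", "measured", "known", "first", "only" and "open" are said of these compounds alone.

Measured in a functional assay on MCF7 cells (Homo sapiens) for antiproliferative activity, read by MTT assay, with a stated time of 48 h; on this read-out higher numbers stand for weaker inhibition and lower numbers for stronger inhibition:
compound 1 `CCC(C)C(NC(=O)c1ccc(C(CC)(CC)c2ccc(OCCC(O)(CC)CC)c(C)c2)n1CC)C(=O)O`: 11300 nM
compound 2 `CCn1c(C(=O)NC(CC(=O)O)C(=O)OC)ccc1C(CC)(CC)c1ccc(OCCC(O)(CC)CC)c(C)c1`: 10200 nM

Within the data shown here, compound 2, at 10200 nM, stands level with compound 1, the only other measured member of the series. Among the measured compounds shown here, the one measured step, a 1.1-fold lower number from compound 1 to compound 2 (0.04 log units; within the scatter), is an exchange of one open-chain group for another on an amide-type nitrogen.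

Compound 3 `CCC(C)C(CO)NC(=O)c1ccc(C(CC)(CC)c2ccc(OCCC(O)(CC)CC)c(C)c2)n1CC` changes that same place. Its difference from compound 2 is a group of 7 heavy atoms (6 carbon, 1 oxygen; no ring) in place of a group of 9 heavy atoms (5 carbon, 4 oxygen; no ring), on an amide-type nitrogen. The entering group is 1-(hydroxymethyl)-2-methylbutyl, with no net charge, as for the group that leaves.

For the measured compounds named here, only one measured step bears on this exchange, and it is a thin basis: the data hold no compound with this entering group. Going by the step from compound 1 to compound 2, a 1.1-fold lower number from compound 1 to compound 2 (0.04 log units; within the scatter), no change beyond the scatter is expected in this assay, and no firm direction can be given. The expected change is small, an estimated 1.1-fold lower number from compound 2 to compound 3 (0.05 log units; within the scatter). For compound 3 the expected value is 9000 nM, with an estimated range of 3500 nM to 23000 nM.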

Compound 3, half-maximal inhibitory concentration: 29100 nM
Beside the measured number, compound 3's estimate is 3.2-fold (0.51 log units) below it, outside the stated range (above it).
By their numbers in this assay, from the lowest: compounds 2 and 1 (each within the scatter of the next); then compound 3.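

In this assay this place on the amide-type nitrogen is no longer flat: the two earlier groups gave no separable numbers, whereas 1-(hydroxymethyl)-2-methylbutyl gives a 2.9-fold higher number from compound 2 to compound 3 (0.46 log units; beyond the scatter) and the step is modest. The cleanest reading is the exchange of hydroxymethyl for carboxy on a saturated chain carbon bound to an amide-type nitrogen and a saturated chain carbon, which gives a 2.6-fold higher number from compound 1 to compound 3 (0.41 log units; beyond the scatter) with the rest of the molecule unchanged, so within these three compounds the two groups carrying a carboxy sit level and the one without it gives the higher number, though a single compound without carboxy cannot establish a trend. Nothing available accounts for this step.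

Going by these compounds, whether the carboxy group itself matters remains open, since a methyl ester, a primary carboxamide or an amine at the same chain carbon of compound 1 would separate the carboxy group from other replacements. Also open, on these data alone, is whether a longer chain between that carbon and the carboxylic acid, or a hydroxymethyl group on the shorter frame of compound 2, would move the number beyond the scatter.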